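Cytotoxicity of Three Measured Compounds and One Ester Swap

This account rests on a few compounds, and the source may have more. Where it says the series, first, only, none or still open, it means among the compounds named here.

Values in an ADME assay on RAW264.7 cells (Mus musculus) for cytotoxicity, read by MTT assay, with a stated time of 24 h; on this read-out higher numbers stand for weaker inhibition and lower numbers for stronger inhibition:
- compound 1 `COc1cc(O)c(C(=O)/C=C/c2ccc(OCCCN3CCCC3)c(OC)c2)c(OC)c1`: > 40000 nM (a limit)
- compound 2 `COc1cc(O)c(C(=O)/C=C/c2ccc(C)cc2)c(OC)c1`: > 40000 nM (a limit)
- compound 3 `CCOc1cc(OC)cc(OC)c1C(=O)/C=C/c1cccc(OC)c1`: 34000 nM

Within the data shown here, compound 3 holds the only true number here. Compound 1 and compound 2 sit at the limit of > 40000 nM in this assay, at which 2 of the 3 values shown sit, and those entries are limits, not numbers.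

Compound 4 `COc1cccc(/C=C/C(=O)c2c(OC)cc(OC)cc2OC(C)=O)c1` changes one place in compound 3: acetyl in place of ethyl on an oxygen on an aromatic ring. Put simply, this is ethoxy to acetoxy. Among the measured compounds shown here, no measured pair shows this swap, so the expectation rests on compound 3 at 34000 nM. No shift beyond the scatter in this assay is expected, in either direction. The expected size of the change is a 1.1-fold lower number from compound 3 to compound 4 (0.03 log units; within the scatter). For compound 4 the estimated value is 32000 nM, with an expected range from 14000 nM to 60000 nM.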

Compound 4, half-maximal inhibitory concentration: 30700 nM
The estimate for compound 4 lay 1.0-fold (0.02 log units) above the measured number; the measured number falls inside the stated range.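

In this assay the change reads a 1.1-fold lower number from compound 3 to compound 4 (0.04 log units; within the scatter). Among these compounds, this is the only measured pair that differs at this oxygen on the aromatic ring, and it shows that ethoxy and acetoxy cannot be told apart here, since the step stays within the scatter.

On these data alone, compound 1 and compound 2 give only limits, not numbers, and so add nothing on this position: the limit of > 40000 nM in this assay, at which 2 of the 4 values shown sit. Whether an amine, a carboxylic acid or a longer chain on this oxygen would move the number beyond the scatter remains open.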